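The source may hold more compounds than are shown below. What is called first, only, known or untested is meant among the compounds shown, and "the series" means these compounds.

Measured in a functional assay on NCI-H460 cells (Homo sapiens) for inhibition, read by sulforhodamine B assay, with a stated time of 48 h; on this read-out lower numbers stand for stronger inhibition of growth and higher numbers for weaker inhibition of growth:
- compound 1 `COc1ccc(-c2c(CNC(C)(C)C)c(C(=O)O)nn2-c2ccccc2)cc1`: > 659000 nM
- compound 2 `CC(C)(C)NCc1c(C(=O)O)nn(-c2ccc(Cl)cc2)c1-c1ccc(F)cc1`: > 623000 nM
- compound 3 `CC(C)(C)NCc1c(C(=O)O)nn(-c2ccc(Cl)cc2)c1-c1ccccc1`: > 652000 nM

Each of these three entries is a limit of the assay and not a number. Compound 3 therefore stands only at its limit of > 652000 nM. Compound 4 `COc1ccc(-c2c(CNC(C)(C)C)c(C(=O)O)nn2-c2ccc(Cl)cc2)cc1` differs from it by methoxy in place of hydrogen on an aromatic carbon, which is methoxy in place of hydrogen on an aromatic carbon, or phenyl to 4-methoxyphenyl. Going by the values given here, the one measured step, a step that the two limits leave unreadable from compound 2 to compound 3, gives no size to work from. Compound 1 already carries the 4-methoxyphenyl, and its entry is the limit > 659000 nM. No step beyond the scatter is therefore expected in this assay, in either direction. The expected change is an at least 1.0-fold lower number from compound 3 to compound 4 (0.02 log units; that floor lies within the scatter). For compound 4 the estimate is 620000 nM, with an expected range of 350000 nM to 900000 nM.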

Compound 4, concentration for 50% growth inhibition: > 605000 nM
Compound 4: only a limit was reported (the forecaster's own chance of this, stated with the estimate: 90%); the middle value lies beyond the limit too.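

Going by these compounds alone, compound 1, compound 2, compound 3 and compound 4 all stand only as limits of the assay, and no step among them can be read in this assay. The compounds shown leave open whether methoxy, fluoro or chloro changes growth inhibition at all.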